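The compounds below may be only part of what the source reports. "The series", "measured", "known", "first", "only" and "open" are said of these compounds alone.

Of the compounds shown here, three have been measured in a functional assay on DU-145 cells (Homo sapiens) for inhibition, read by trypan blue exclusion, with a stated time of 72 h; on this read-out higher numbers stand for weaker inhibition and lower numbers for stronger inhibition. Compound 1 `COC(=O)Cn1c(=O)c(S(=O)(=O)c2ccc(F)cc2F)cc2cnc(Nc3ccc4[nH]ccc4c3)nc21` gives 10000 nM. Compound 3 `Cc1ccc(S(=O)(=O)c2cc3cnc(Nc4ccc5cc[nH]c5c4)nc3n(C)c2=O)cc1` gives 15000 nM, within the usual scatter of compound 1. Compound 2 `COc1ccc(Nc2ncc3cc(S(=O)(=O)c4ccc(C)cc4)c(=O)n(C)c3n2)cc1` gives 100000 nM, a number beyond the scatter above that of compound 1. Compound 1 therefore stands level with compound 3 and clearly apart from compound 2.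

Compound 4 `CCn1c(=O)c(S(=O)(=O)c2ccc(F)cc2F)cc2cnc(Nc3ccc4[nH]ccc4c3)nc21` keeps the core of compound 1 and changes one group: methyl in place of methoxycarbonyl on a saturated chain carbon bound to an aromatic nitrogen. This places methyl in place of methoxycarbonyl on a saturated chain carbon bound to an aromatic nitrogen, so that (methoxycarbonyl)methyl becomes ethyl.

For the measured compounds named here, the only measured step, a 6.7-fold lower number from compound 2 to compound 3 (0.82 log units; beyond the scatter), is modest and beyond the scatter, but it concerns 1H-indol-6-yl in place of 4-methoxyphenyl on a nitrogen on an aromatic ring, not the group that changes here. Going by the values given here, it therefore bears on the new change only loosely, and no measured step isolates that change. With nothing pointing in either direction, no step beyond the scatter is expected in this assay. The estimated step is a 1.1-fold lower number from compound 1 to compound 4 (0.05 log units; within the scatter), and this is expected to remain uncertain in direction. Compound 4 is expected at 9000 nM, with an estimated range from 2000 nM to 40000 nM.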

Compound 4, half-maximal inhibitory concentration: 750 nM
Compound 4: the middle estimate sits 12-fold (1.08 log units) above what was measured; the whole stated range lies above it.
By their numbers in this assay, from the lowest: compound 4; then compounds 1 and 3 (each within the scatter of the next); then compound 2.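

In this assay, replacing (methoxycarbonyl)methyl with ethyl gives a 13-fold lower number from compound 1 to compound 4 (1.12 log units; beyond the scatter), showing that the read-out responds strongly to the group on this aromatic nitrogen. For the compounds shown here, the earlier compounds offered only a modest step for 1H-indol-6-yl in place of 4-methoxyphenyl on a nitrogen on an aromatic ring, so this is the first sign that a second place on the molecule matters, and here the step is rated large. No measurement of any property bears on this step, so the data offer no account of it.

A single pair cannot show whether the number follows the loss of methoxycarbonyl as such or depends on what takes its place, and a carboxylic acid, an amide or a longer chain such as propyl at this place would help separate those readings. As far as these compounds go, it also remains open whether methyl in place of methoxycarbonyl would give a step of similar size with 4-methoxyphenyl rather than 1H-indol-5-yl on the nitrogen on an aromatic ring.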